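Shortening the alkyl chain on the epoxide ester

The source may hold more compounds than are shown below. What is called first, only, known or untested is meant among the compounds shown, and "the series" means these compounds.

Going by the values given here, compound 2 `CCCCCCCCCCCCC1(C(=O)OC)CO1` gives 600 nM in an assay on isolated protein (Rattus norvegicus) for inhibition of carnitine palmitoyltransferase 1A (Sus scrofa) (a higher number here means a weaker inhibitor, a lower number a stronger inhibitor), the top of the two numbers in hand, while the only step to it, a 2.0-fold higher number from compound 1 to compound 2 (0.30 log units; within the scatter), stays within the scatter. In this assay compound 1 `CCCCCCCCCCCCCCC1(C(=O)OC)CO1` gives 300 nM. Compound 3 `CCCCCCCCCCC1(C(=O)OC)CO1` repeats the same kind of cut: hydrogen in place of ethyl on a saturated chain carbon, ten or more bonds along the chain from a saturated ring carbon. Among the compounds with values here, that earlier step is the sole guide, so a step of similar size, toward a higher number but not clearly beyond the scatter, is expected. Compound 3 is estimated at 1400 nM, range 500 nM to 4500 nM, an expected step of a 2.3-fold higher number from compound 2 to compound 3 (0.37 log units; beyond the scatter).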

Compound 3, half-maximal inhibitory concentration: 680 nM
Beside the measured number, compound 3's estimate is 2.1-fold (0.31 log units) above it; measured number inside the range.
By their numbers in this assay, from the lowest: compounds 1, 2 and 3 (each within the scatter of the next, the first and the last beyond it).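

The second cut of this kind, ethyl to hydrogen on the chain, gives a 1.1-fold higher number from compound 2 to compound 3 (0.05 log units; within the scatter), so compound 2 and compound 3 cannot be told apart in this assay. Only the whole shortening, butyl to hydrogen, clears the scatter, with a 2.3-fold higher number from compound 1 to compound 3 (0.36 log units; beyond the scatter), and that rise is modest. No evidence in hand bears on this dependence on chain length.

Open, as far as these compounds go, is whether a longer chain than that of compound 1 lowers the number further. Also open, from the compounds shown here alone, is whether a carboxylic acid in place of the ester keeps the same trend with chain length.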